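The compounds below may be only part of what the source reports. "The series", "measured", "known", "first", "only" and "open" are said of these compounds alone.

Measured so far:
compound 1 `Cc1ccccc1-c1noc(-c2ccc(C3CCCCC3)cc2)n1` — 266 nM
compound 2 `Cc1cc(CCC(=O)O)ccc1-c1noc(-c2ccc(OC(C(F)(F)F)C(F)(F)F)c(C#N)c2)n1` — 0.7 nM

In a functional assay on CHO cells for agonist activity at sphingosine 1-phosphate receptor 5 (Homo sapiens), read by GTPgammaS binding (on this read-out higher numbers stand for an effect only at larger amounts of compound and lower numbers for an effect already at smaller amounts), compound 1 gives 266 nM, the higher of the two numbers; compound 2, which carries a different group on its other aryl ring as well as an acid side chain, gives 0.7 nM, a far lower number, well beyond the scatter. For the measured compounds named here, no pair differing in one place has been measured. How much of that gap comes from the acid chain alone therefore cannot be read off.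

Compound 3 `Cc1cc(CCC(=O)O)ccc1-c1noc(-c2ccc(C3CCCCC3)cc2)n1` is not yet measured. It differs from compound 1 by 2-carboxyethyl in place of hydrogen on an aromatic carbon. Given that compound 2, with the same chain on the same ring, gives 0.7 nM, the step is expected to be a clear decrease in this assay, beyond the scatter, though smaller than the whole gap between compound 1 and compound 2. The estimate for compound 3 is 15 nM (range 3 nM to 80 nM), corresponding to an expected step of an 18-fold lower number from compound 1 to compound 3 (1.25 log units; beyond the scatter).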

Compound 3, half-maximal effective concentration: 591 nM
The estimate for compound 3 lay 39-fold (1.60 log units) below the measured number; the measured number lies above the stated range.
By their numbers in this assay, from the lowest: compound 2; then compound 1; then compound 3.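

In this assay the swap of hydrogen for 2-carboxyethyl on this aromatic carbon, meta to a methyl group and para to a large group, gives a 2.2-fold higher number from compound 1 to compound 3 (0.35 log units; beyond the scatter) with the rest of compound 1 unchanged. On this background the chain alone therefore brings no lowering of the number, so the chain cannot by itself account for the low number of compound 2 at 0.7 nM in this series. Nothing available explains the direction of this step.

Open, going by these compounds, is whether the same chain would lower the number when the other aryl ring carries the nitrile and the ether group of compound 2. Also open, on these data alone, is how a shorter carboxymethyl group, a longer carboxypropyl chain or a primary amine on the same chain would read at this position in this assay on either background.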